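Removal of the triazole aryl group in the shared core

The source may hold more compounds than are shown below. What is called first, only, known or untested is meant among the compounds shown, and "the series" means these compounds.

Compound 1 `O=C1O[C@H]([C@@H](O)Cn2cc(-c3cccc(O)c3)nn2)C(OCc2ccccc2)=C1OCc1ccccc1`: in a functional assay on HepG2 cells (Homo sapiens) for antiproliferative activity, read by MTT assay, with a stated time of 72 h (on this read-out lower numbers stand for stronger inhibition and higher numbers for weaker inhibition), compound 1 gives 62700 nM.
Compound 2 `O=C1O[C@H]([C@@H](O)Cn2cc(CCO)nn2)C(OCc2ccccc2)=C1OCc1ccccc1`: in this assay compound 2 gives 68100 nM.
Compound 3 `CCCCCc1ccc(-c2cn(C[C@H](O)[C@H]3OC(=O)C(OCc4ccccc4)=C3OCc3ccccc3)nn2)cc1`: in this assay compound 3 gives 7460 nM.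

Compound 3 has the lowest number of the three; compound 1 is nearest to it and compound 2 furthest, both gaps beyond the scatter. Compound 4 `O=C1O[C@H]([C@@H](O)Cn2ccnn2)C(OCc2ccccc2)=C1OCc1ccccc1` differs from compound 3 by hydrogen in place of 4-pentylphenyl on an aromatic carbon. Going by the values given here, two measured steps bear on this change: an 8.4-fold lower number from compound 1 to compound 3 (0.92 log units; beyond the scatter) and a 9.1-fold lower number from compound 2 to compound 3 (0.96 log units; beyond the scatter). Both show that placing 4-pentylphenyl on that aromatic carbon gave a modest lowering of the number. Taking the group away to leave hydrogen is therefore expected to undo that lowering, with a step of an 8.0-fold higher number from compound 3 to compound 4 (0.91 log units; beyond the scatter) in this assay. Compound 4 is expected to give 60000 nM, within a range of 25000 nM to 150000 nM.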

Compound 4, half-maximal inhibitory concentration: > 100000 nM
Compound 4: only a limit was reported; the forecaster's own chance of this, stated with the estimate: 15%; at least 1.6-fold (0.22 log units) between middle value and limit.
By their numbers in this assay, from the lowest: compound 3; then compounds 1 and 2 (each within the scatter of the next). At a limit, above all of these: compound 4.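

Compound 4 gives only a limit: the limit of > 100000 nM in this assay, at which 1 of the 4 values shown sits. Against 4-pentylphenyl, hydrogen on this aromatic carbon gives a large step, an at least 13-fold higher number from compound 3 to compound 4 (1.12 log units; beyond the scatter), while the floors of an at least 1.4-fold higher number from compound 2 to compound 4 (0.16 log units; that floor lies within the scatter) and an at least 1.5-fold higher number from compound 1 to compound 4 (0.20 log units; that floor lies within the scatter) lie within the scatter, so hydrogen is not separated from 2-hydroxyethyl or 3-hydroxyphenyl. Of the four substituents shown, only 4-pentylphenyl stands clear of the others in this assay. Still open, as far as these compounds go, is whether the lowering belongs to the pentyl chain or to the phenyl ring. An unsubstituted phenyl, a longer alkyl chain or an amine at this carbon would bear on that.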